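The source may hold more compounds than are shown below. What is called first, only, known or untested is meant among the compounds shown, and "the series" means these compounds.

Of the compounds shown here, three of a shared core have been measured in a functional assay on HT-1080 cells (Homo sapiens) for antiproliferative activity, read by sulforhodamine B assay, with a stated time of 48 h; a lower number here means a stronger inhibitor, a higher number a weaker inhibitor. Compound 1 `NS(=O)(=O)c1ccc(N/C(S)=N\c2ccnc3cc(C(F)(F)F)ccc23)cc1` gives 31000 nM. Compound 2 `CC(=O)NS(=O)(=O)c1ccc(N/C(S)=N\c2ccnc3cc(C(F)(F)F)ccc23)cc1` gives 28300 nM. Compound 3 `Cc1cc(NS(=O)(=O)c2ccc(N/C(S)=N\c3ccnc4cc(C(F)(F)F)ccc34)cc2)on1` gives 27300 nM, the lowest of the three numbers, though its steps to the others stay within the scatter: a 1.1-fold lower number from compound 1 to compound 3 (0.06 log units; within the scatter) and a 1.0-fold lower number from compound 2 to compound 3 (0.02 log units; within the scatter), as does a 1.1-fold lower number from compound 1 to compound 2 (0.04 log units; within the scatter). The three sulfonamide-nitrogen substituents, hydrogen, acetyl and 3-methyl-1,2-oxazol-5-yl, therefore give indistinguishable results in this assay.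

Compound 4 `Cc1noc(NS(=O)(=O)c2ccc(N/C(S)=N\c3ccnc4cc(C(F)(F)F)ccc34)cc2)c1C` differs from compound 3 by methyl in place of hydrogen on an aromatic carbon, a methyl in place of hydrogen on an aromatic carbon of the 3-methyl-1,2-oxazol-5-yl group. Among the measured compounds shown here, no measured step alters this same ring, but the three measured steps that exchange the whole group on the sulfonamide nitrogen all fall within the scatter, so a further methyl on that group is expected to yield no step beyond the scatter. Compound 4 is estimated to give 27000 nM in this assay, within 12000 nM to 60000 nM, meaning an expected step of a 1.0-fold lower number from compound 3 to compound 4 (0.00 log units; within the scatter).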

Compound 4, half-maximal inhibitory concentration: 27700 nM
Beside the measured number, compound 4's estimate is 1.0-fold (0.01 log units) below it, within the range that was stated.
By their numbers in this assay, from the lowest: compounds 3, 4, 2 and 1 (each within the scatter of the next).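

In this assay, among the compounds shown here, this is the first change made on the ring of the sulfonamide substituent itself, rather than an exchange of the whole group, and the methyl on this aromatic carbon gives a 1.0-fold higher number from compound 3 to compound 4 (0.01 log units; within the scatter). The 3,4-dimethyl-1,2-oxazol-5-yl group also stays level with the other substituents on the sulfonamide nitrogen, with a 1.0-fold lower number from compound 2 to compound 4 (0.01 log units; within the scatter) and a 1.1-fold lower number from compound 1 to compound 4 (0.05 log units; within the scatter), so this position shows no response to methyl in place of hydrogen. Nothing available offers an explanation for this result.

The compounds shown leave open whether an amine, a carboxylic acid or a longer chain on this ring carbon would give a step beyond the scatter. They also leave open whether any change elsewhere on the shared core would do so.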